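The compounds below may be only part of what the source reports. "The series", "measured", "known", "first", "only" and "open" are said of these compounds alone.

Compound 1, `O=C(O)Cc1ccc(C(=O)O)nc1`, is the stronger of the two compounds that have a number in an assay on isolated protein (Gallus gallus) for inhibition of transmembrane prolyl 4-hydroxylase (Homo sapiens); a higher number here means a weaker inhibitor, a lower number a stronger inhibitor: in this assay compound 1 gives 9600 nM, and compound 2, `O=C(O)c1ccc(C(Cc2ccccc2)C(=O)O)cn1`, gives 27000 nM, a gap that lies beyond the usual scatter. Compound 3, `O=C(O)CCc1ccc(C(=O)O)nc1`, has not yet been measured. It differs from compound 1 in one place: carboxymethyl in place of carboxy on a saturated chain carbon bound to an aromatic carbon, so that the acid on the chain is moved one carbon further from the shared core while the acid on the core itself is kept.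

Among the measured compounds shown here, no measured pair tells how a lengthening of this chain plays out in this assay, and compound 2, which carries a benzyl group on the chain carbon instead, is the only other point of reference. A step that lengthens the chain is therefore expected to cost some strength rather than gain it, and the step of a 1.6-fold higher number from compound 1 to compound 3 (0.19 log units; within the scatter) is estimated to be small, at the edge of the scatter. On this basis compound 3 is expected to give about 15000 nM in this assay, with a plausible range from 5000 nM to 50000 nM.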

Compound 3, half-maximal inhibitory concentration: 9600 nM
Beside the measured number, compound 3's estimate is 1.6-fold (0.19 log units) above it; the measured number falls inside the stated range.
By their numbers in this assay, from the lowest: compounds 1 and 3 (each within the scatter of the next); then compound 2.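

In this assay, among the compounds shown here, the exchange of carboxy for carboxymethyl on a saturated chain carbon bound to an aromatic carbon gives no change at the digits printed from compound 1 to compound 3 (within the scatter) and is the first step at this position that can be read. The earlier compounds shown here offered no matched pair, whereas this one shows that moving the acid on the chain one carbon further from the shared core, with the acid on the core kept, leaves the number in this assay unmoved. The step shows that this position accepts this one lengthening, though a single step cannot set the limit of what the position accepts, and no measurement at hand offers an explanation for the flat result.

For the compounds shown here, it remains open whether a still longer chain, such as carboxypropyl, would leave the number equally unmoved, or whether the first step of lengthening is a special case. The compounds shown also leave open what the acid at the end of the chain contributes, since a chain ending in a hydroxyl group, an amine or a plain methyl group would be needed to separate the acid from the chain itself.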